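Replacing a side chain with sec-butyl in a free-acid compound

The source may report more compounds than this note shows. Statements on the series, on what has been measured and on what is new or still open speak of the compounds shown alone.

Measured so far:
- compound 1, `C[C@H](NC(=O)CN(c1nc(Cl)nc2[nH]cnc12)C1CC1)C(=O)OCc1ccccc1`: 23%
- compound 2, `N=C(N)NCCC[C@H](NC(=O)CN(c1nc(Cl)nc2[nH]cnc12)C1CC1)C(=O)O`: 7.19%
- compound 3, `CC(C)[C@H](NC(=O)CN(c1nc(Cl)nc2[nH]cnc12)C1CC1)C(=O)OCc1ccccc1`: 17.9%

All three share one core and differ only in the group on the saturated chain carbon bound to an amide-type nitrogen and a carbonyl carbon, and in whether the acid end is free or capped as a benzyl ester. In a functional assay on the whole organism (Tail, strain ICR) with Mus musculus as the target, in the tail flick test, with a stated time of 150 min, at a dose of 25 umol/kg by the oral route (a higher number here means a stronger effect of the compound at the dose given, a lower number a weaker effect), compound 2 stands lowest of the three, beyond the scatter below both compound 3 and compound 1. Compound 4, `CC[C@H](C)[C@H](NC(=O)CN(c1nc(Cl)nc2[nH]cnc12)C1CC1)C(=O)O`, is not yet measured; it keeps the free acid of compound 2 and changes only the side chain: a group of 4 heavy atoms (4 carbon; no ring) in place of a group of 7 heavy atoms (4 carbon, 3 nitrogen; no ring), on a saturated chain carbon bound to an amide-type nitrogen and a carbonyl carbon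

Among the compounds with values here, only one measured step touches that position, a number 5.1 percentage points lower from compound 1 to compound 3 (within the scatter), and it compares two benzyl esters, not two free acids, so it speaks to compound 4 only indirectly. It suggests that swapping one small carbon side chain for another changes little. Within the data shown here, no measured pair shows what removing the three-nitrogen group does. With that, the step in this assay is expected to be small, perhaps slightly upward, as a number 4.8 percentage points higher from compound 2 to compound 4 (within the scatter), since the two ester compounds with plain carbon side chains sit higher than compound 2. Compound 4 is therefore estimated at 12%, with a range from 2% to 26%.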

Compound 4, a percentage reported as activity, at one dose (the size of the read-out at that dose, not a potency): 6.71%
For compound 4 the middle estimate is 5.3 percentage points above the measured one, and the stated range covers the measured number.
By their numbers in this assay, from the lowest: compounds 4 and 2 (each within the scatter of the next); then compounds 3 and 1 (each within the scatter of the next).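

Among free acids, the exchange on the saturated chain carbon bound to an amide-type nitrogen and a carbonyl carbon now has a measured step in this assay: a number 0.5 percentage points lower from compound 2 to compound 4 (within the scatter). Putting sec-butyl, with 0 hydrogen-bond donors, in place of the group of 7 heavy atoms, with its 3 nitrogen atoms and 3 hydrogen-bond donors, leaves these two free acids indistinguishable in this read-out, something the earlier pair of benzyl esters, which swapped one small carbon side chain for another, could not show. No measurement is available that accounts for this result.

The compounds shown include no pair that differs only at the acid end, so it remains open whether a benzyl ester carrying the sec-butyl side chain would read differently from compound 4. From the compounds shown here alone, it is also open whether a free acid with a side chain ending in an amine or a carboxylic acid, or with a longer plain carbon chain, would stay level with compound 2 and compound 4 at this dose.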